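Replacing propyl with 3-methoxyphenyl in compound 1

This account rests on a few compounds, and the source may have more. Where it says the series, first, only, none or still open, it means among the compounds named here.

In a functional assay on HCT-15 cells (Homo sapiens) for antiproliferative activity, read by MTT assay, with a stated time of 72 h (on this read-out higher numbers stand for weaker inhibition and lower numbers for stronger inhibition), compound 1 `CCCn1ccnc1-c1cc(OC)c(OC)c(OC)c1` gives > 100000 nM, which is a limit of the assay and not a number. Compound 2 `COc1cc(-c2nccn2S(=O)(=O)c2ccccc2)cc(OC)c1OC` gives > 100000 nM, also a limit. Compound 3 `COc1cc(-c2nccn2S(=O)(=O)c2ccc(C)cc2)cc(OC)c1OC` gives > 100000 nM, again a limit. All three therefore sit at one place, (the limit of > 100000 nM in this assay, at which 3 of the 3 values shown sit).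

Compound 4 `COc1cccc(-n2ccnc2-c2cc(OC)c(OC)c(OC)c2)c1` keeps the core of compound 1 and changes one group, with 3-methoxyphenyl in place of propyl on an aromatic nitrogen.

Within the data shown here, the only measured step is a step that the two limits leave unreadable from compound 2 to compound 3, and it concerns a methyl in place of hydrogen on an aromatic carbon, so it offers no size to carry over. The data fix no size for the new change. From a limit, the only readable movement in this assay is towards stronger inhibition, and compound 4 may well stay at the limit too.

The expected change is an at least 6.6-fold lower number from compound 1 to compound 4 (0.82 log units; beyond the scatter). For compound 4 the estimated value is 15000 nM, with an expected range from 800 nM to 100000 nM.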

Compound 4, half-maximal inhibitory concentration: 17100 nM
Beside the measured number, compound 4's estimate is 1.1-fold (0.06 log units) below it; the range from low to high includes it.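

In this assay, 3-methoxyphenyl in place of propyl on an aromatic nitrogen gives an at least 5.8-fold lower number from compound 1 to compound 4 (0.76 log units; beyond the scatter), the first readable movement in this small set. As far as these compounds go, compound 1 carries a limit and not a number, so the step shows only that this position can respond to a change, and its true size stays unknown. Compound 4, at 17100 nM, is the only compound shown with a measured number, while the others remain at one place: the limit of > 100000 nM in this assay, at which 3 of the 4 values shown sit.

The aromatic ring and its methoxy group enter together, so a plain phenyl on this nitrogen would be needed to show whether the ring alone is enough. The step between compound 2 and compound 3 cannot be read, which leaves the effect of the methyl on that aromatic carbon open.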